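The source may report more compounds than this note shows. Statements on the series, on what has been measured and on what is new or still open speak of the compounds shown alone.

Working notes on the series. The shared core is that of compound 1 `Clc1ccc(C2CC(c3ccc(N4CCCCC4)cc3)=NN2c2nc(-c3ccccc3)cs2)cc1`, which in a functional assay on A549 cells (Homo sapiens) for antiproliferative activity, read by MTT assay, with a stated time of 72 h (on this read-out lower numbers stand for stronger inhibition and higher numbers for weaker inhibition), gives 64200 nM. Compound 2 `O=[N+]([O-])c1ccc(-c2csc(N3N=C(c4ccc(N5CCCCC5)cc4)CC3c3ccc(Cl)cc3)n2)cc1` carries nitro in place of hydrogen on an aromatic carbon. In this assay compound 2 returns only a limit, > 100000 nM, as set out in the limit of > 100000 nM in this assay, at which 1 of the 3 values shown sits. Compound 3 `N#Cc1ccc(-c2csc(N3N=C(c4ccc(N5CCCCC5)cc4)CC3c3ccc(Cl)cc3)n2)cc1` carries cyano at the same aromatic carbon, and in this assay compound 3 gives 11200 nM, the lowest of the two numbers recorded; compound 1 is nearest. The measured steps are a 5.7-fold lower number from compound 1 to compound 3 (0.76 log units; beyond the scatter), an at least 1.5-fold higher number from compound 1 to compound 2 (0.19 log units; that floor lies within the scatter) and an at least 8.9-fold lower number from compound 2 to compound 3 (0.95 log units; beyond the scatter).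

Compound 4 `FC(F)(F)c1ccc(-c2csc(N3N=C(c4ccc(N5CCCCC5)cc4)CC3c3ccc(Cl)cc3)n2)cc1` differs from compound 3 by trifluoromethyl in place of cyano on an aromatic carbon. Among the measured compounds shown here, no measured step exchanges cyano for trifluoromethyl, so the direction is not fixed by precedent. The steps show that the group at this aromatic carbon moves the number: cyano lowered it from compound 1 (a 5.7-fold lower number from compound 1 to compound 3 (0.76 log units; beyond the scatter)), whereas nitro did not (an at least 1.5-fold higher number from compound 1 to compound 2 (0.19 log units; that floor lies within the scatter)). Trifluoromethyl is a third substituent without a measured counterpart; the guarded expectation is a number that gives back part of the gain of compound 3. For compound 4 in this assay the step is estimated as a 2.0-fold higher number from compound 3 to compound 4 (0.29 log units; within the scatter). Compound 4 is therefore expected to give about 22000 nM, in the range 7000 nM to 70000 nM.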

Compound 4, half-maximal inhibitory concentration: 42000 nM
For compound 4 the middle estimate is 1.9-fold (0.28 log units) below the measured one, and the stated range covers the measured number.
By their numbers in this assay, from the lowest: compound 3; then compounds 4 and 1 (each within the scatter of the next). At a limit, above all of these: compound 2.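

In this assay the exchange of cyano for trifluoromethyl at this aromatic carbon is not a neutral swap, with a 3.8-fold higher number from compound 3 to compound 4 (0.57 log units; beyond the scatter) as its measured step, and the lower number of compound 3 therefore does not carry over to this second 4-substituted phenyl group. Against the hydrogen of the shared core the picture is a 1.5-fold lower number from compound 1 to compound 4 (0.18 log units; within the scatter) and so compound 4 cannot be told apart from compound 1, which leaves cyano as the only one of the three groups shown with a step from hydrogen to a lower number beyond the scatter, while the nitro comparison gives an at least 2.3-fold lower number from compound 2 to compound 4 (0.37 log units; beyond the scatter) as a separate separation among the substituted compounds. Compound 2 stands only at a limit, so that last step is a floor: the limit of > 100000 nM in this assay, at which 1 of the 4 values shown sits.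

On these data alone, whether an amine, a carboxylic acid or a methoxy group at this carbon would reach the number of compound 3 stays open. Also open, as far as these compounds go, is whether the cyano step holds when the group sits elsewhere on this six-membered aromatic ring or when other parts of the shared core change.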